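Moving the thiophene attachment point on a coumarin-type scaffold

This account rests on a few compounds, and the source may have more. Where it says the series, first, only, none or still open, it means among the compounds named here.

Measured compounds:
compound 1, `CC(=O)Oc1ccc2cc(-c3cccs3)c(=O)oc2c1OC(C)=O`, 22500 nM
compound 2, `CC(=O)Oc1ccc2cc(-c3ccsc3)c(=O)oc2c1OC(C)=O`, 3600 nM
compound 3, `O=c1oc2c(O)cccc2cc1-c1cccs1`, 1430 nM

In an assay on CHO cells for displacement of a labelled ligand from transmembrane domain-containing protein TMIGD3 (Homo sapiens) (on this read-out lower numbers stand for stronger inhibition and higher numbers for weaker inhibition), compound 1 gives 22500 nM. Compound 2 differs from compound 1 by thiophen-3-yl in place of thiophen-2-yl on an aromatic carbon; in this assay compound 2 gives 3600 nM, so that step is a 6.3-fold lower number from compound 1 to compound 2 (0.80 log units; beyond the scatter). Compound 3 gives 1430 nM; the difference between the core of compound 3 and the core of compound 1 is not broken down here.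

Compound 4, `O=c1oc2c(O)cccc2cc1-c1ccsc1`, has not been measured yet. It differs from compound 3 by thiophen-3-yl in place of thiophen-2-yl on an aromatic carbon, the same change seen between compound 1 and compound 2, at the same place. Because the step of a 6.3-fold lower number from compound 1 to compound 2 (0.80 log units; beyond the scatter) was clearly beyond the scatter, a step in the same direction is expected here, though it may be smaller on this different core: the expected step is a 2.9-fold lower number from compound 3 to compound 4 (0.46 log units; beyond the scatter). The estimated value for compound 4 in this assay is 500 nM, with a likely range from 150 nM to 1500 nM.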

Compound 4, inhibition constant: 2870 nM
Compound 4: middle estimate off by 5.7-fold (0.76 log units), on the low side; the measured number lies above the stated range.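

On the second core, swapping thiophen-2-yl for thiophen-3-yl gives a 2.0-fold higher number from compound 3 to compound 4 (0.30 log units; within the scatter), so in this assay the two attachment points cannot be told apart there. Among the compounds shown here, the clear gain seen on the first core therefore did not carry over, and the two steps really do differ: the same change on two cores in this assay, a 6.3-fold lower number (0.80 log units; beyond the scatter) from compound 1 to compound 2 and a 2.0-fold higher number (0.30 log units; within the scatter) from compound 3 to compound 4, 13-fold (1.10 log units) apart, beyond the scatter of two such steps This rests on only two pairs, and it does not show which feature of the cores is responsible or how the swap would behave on any further core.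

The compounds shown leave open how the two thiophene attachments would compare on a core carrying a methoxy group in place of the hydroxyl. They also leave open whether a phenyl or furan-2-yl ring at the same place would give a different reading.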